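The source may hold more compounds than are shown below. What is called first, only, known or untested is meant among the compounds shown, and "the series" means these compounds.

Measured so far:
compound 1 `CCCc1cc(N)c2cc(NC(=O)CCc3ccccc3)ccc2n1` gives 8300 nM in an assay on isolated protein for displacement of a labelled ligand from melanin-concentrating hormone receptor 1 (Homo sapiens); a higher number here means a weaker inhibitor, a lower number a stronger inhibitor;
compound 2 `CCCc1cc(NC)c2cc(NC(=O)/C=C/c3ccc(C(F)(F)F)cc3)ccc2n1` gives 1.5 nM;
compound 3 `CCCc1cc(OC)c2cc(NC(=O)/C=C/c3ccc(C(F)(F)F)cc3)ccc2n1` gives 26 nM.

Among these three, compound 1 stands with the highest number, so it is the weakest binder of the set; compound 3 is its nearest neighbour, and compound 2 the furthest. Going by the values given here, the one measured step, from the methylamino of compound 2 to the methoxy of compound 3, gives a 17-fold higher number from compound 2 to compound 3 (1.24 log units; beyond the scatter).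

Compound 4 `CCCc1cc(N)c2cc(NC(=O)/C=C/c3ccccc3)ccc2n1` is compound 1 with one change: 2-phenylethenyl in place of phenethyl on a carbonyl carbon. Among the compounds with values here, no measured step concerns this change, since the step from compound 2 to compound 3 alters a group on the core and leaves the amide side unchanged. What the data do show is that compound 2 and compound 3, both carrying a 2-phenylethenyl amide, reach far lower numbers than compound 1, though each also differs from compound 1 at two other places, so the share of the double bond in that gap cannot be separated.

Compound 4 is therefore expected to give a lower number than compound 1, with the step of a 28-fold lower number from compound 1 to compound 4 (1.44 log units; beyond the scatter) being an estimate of uncertain size. The expected value for compound 4 is 300 nM, in a range from 30 nM to 3000 nM.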

Compound 4, half-maximal inhibitory concentration: 1000 nM
For compound 4 the middle estimate is 3.3-fold (0.52 log units) below the measured one; measured number inside the range.
By their numbers in this assay, from the lowest: compound 2; then compound 3; then compound 4; then compound 1.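

In this assay, going by these compounds alone, putting 2-phenylethenyl in place of phenethyl on the carbonyl carbon gives an 8.3-fold lower number from compound 1 to compound 4 (0.92 log units; beyond the scatter), the first measured step at this place that leaves the rest of the molecule unchanged. Both groups have the same count of heavy atoms, all carbon, and the same six-membered aromatic ring, so the step can be assigned to the one double bond outside aromatic rings, at least on a core that carries a plain amino group. Nothing measured here shows why this double bond lowers the number.

On these data alone, compound 4 still differs from compound 2 in two places, the methyl group on the amino nitrogen and the trifluoromethyl group on the phenyl ring, so the share of each change in the remaining gap between their numbers stays unknown. Also open, as far as these compounds go, is how the number would move with a triple bond in place of this double bond, or with a chlorine atom in place of the trifluoromethyl group.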